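Neopentyl to 1-Cyclohexylethyl on the Imine Nitrogen

This account rests on a few compounds, and the source may have more. Where it says the series, first, only, none or still open, it means among the compounds named here.

Three compounds have been examined in a functional assay for inhibition, with Rattus norvegicus as the target; a higher number here means a weaker inhibitor, a lower number a stronger inhibitor: compound 1 `Nc1c(Nc2cccnc2)c(=O)c1=O`, compound 2 `CSc1ccc(Nc2c(NC(C)C(C)(C)C)c(=O)c2=O)cc1` and compound 3 `CC(C)(C)C/N=c1\c(O)c(O)\c1=N/c1ccc(C#N)cc1`. For compound 1 the read-out is only a limit of the assay, > 30000 nM. For compound 2 the read-out is likewise only a limit, > 30000 nM. Compound 3 also returns only a limit, > 30000 nM. Among the measured compounds shown here, compound 3 thus stands where every value so far sits, at the limit of > 30000 nM in this assay, at which 3 of the 3 values shown sit, and no step between measured compounds can be drawn from these numbers. Compound 4 `C[C@H](/N=c1\c(O)c(O)\c1=N/c1ccc(C#N)cc1)C1CCCCC1` awaits measurement in this assay; it differs from compound 3 in one place: 1-cyclohexylethyl in place of neopentyl on a double-bonded nitrogen. Because compound 3 sits at the limit of > 30000 nM in this assay, at which 3 of the 3 values shown sit, no direction can be read for this change, and a step of a number no higher from compound 3 to compound 4 (the limit leaves the size open) is expected, with the read-out most likely remaining a limit. Compound 4 is therefore estimated at 30000 nM, within a range from 5000 nM to 100000 nM.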

Compound 4, half-maximal inhibitory concentration: > 30000 nM
Compound 4 gave a limit, no number; the forecaster's own chance of this, stated with the estimate: 70%; the middle value sits exactly at the limit.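

In this assay, among the compounds shown here, compound 3 and compound 4 both return only a limit, so no step between them can be read: the limit of > 30000 nM in this assay, at which 4 of the 4 values shown sit. The compounds shown leave open whether any change to the shared core would give a read-out that is a number.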